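A Propyl for Isopropyl Swap on a Carbonyl Carbon

This account rests on a few compounds, and the source may have more. Where it says the series, first, only, none or still open, it means among the compounds named here.

Of the compounds shown here, three sharing one core have been measured in an ADME assay on HepG2 cells (Homo sapiens) for cytotoxicity, read by neutral red uptake, with a stated time of 24 h; a lower number here means a stronger inhibitor, a higher number a weaker inhibitor. Compound 1 (`CC(C)c1cc2c3c(c1OC(=O)CCl)OC(=O)[C@@]31CCCC(C)(C)[C@@H]1CC2`) gives 203000 nM, compound 2 (`CC(C)C(=O)Oc1c(C(C)C)cc2c3c1OC(=O)[C@@]31CCCC(C)(C)[C@@H]1CC2`) gives 112000 nM, and compound 3 (`CCC(=O)Oc1c(C(C)C)cc2c3c1OC(=O)[C@@]31CCCC(C)(C)[C@@H]1CC2`) gives 196000 nM. Compound 2 therefore stands level with the other two, since the data show a 1.8-fold lower number from compound 1 to compound 2 (0.26 log units; within the scatter) and a 1.8-fold higher number from compound 2 to compound 3 (0.24 log units; within the scatter).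

Compound 4 (`CCCC(=O)Oc1c(C(C)C)cc2c3c1OC(=O)[C@@]31CCCC(C)(C)[C@@H]1CC2`) has not yet been measured. It differs from compound 2 as follows: propyl in place of isopropyl on a carbonyl carbon. In words, this is propyl in place of isopropyl on a carbonyl carbon, and the two compounds have the same atoms, joined differently.

The closest evidence comes from changes to the same chain. Trimming the isopropyl group gave a 1.8-fold higher number from compound 2 to compound 3 (0.24 log units; within the scatter), with hydrogen in place of methyl, and exchanging the end of the chain gave a 1.0-fold lower number from compound 1 to compound 3 (0.02 log units; within the scatter), with methyl in place of chloro. Neither change moved this assay beyond the scatter, so no step beyond the scatter is expected here, in either direction. The expected step is a 1.3-fold higher number from compound 2 to compound 4 (0.13 log units; within the scatter). For compound 4 the estimated value is 150000 nM, with an expected range from 85000 nM to 260000 nM.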

Compound 4, half-maximal inhibitory concentration: 56100 nM
Beside the measured number, compound 4's estimate is 2.7-fold (0.43 log units) above it; measured number outside the range, below it.
By their numbers in this assay, from the lowest: compounds 4, 2, 3 and 1 (each within the scatter of the next, the first and the last beyond it).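

Among the compounds shown before it, no change to the chain on this carbonyl carbon had moved the number beyond the scatter, and compound 4 supplies the first two such steps in this assay with a 3.5-fold lower number from compound 3 to compound 4 (0.54 log units; beyond the scatter) and with a 3.6-fold lower number from compound 1 to compound 4 (0.56 log units; beyond the scatter) so this position can shift the reading, though only modestly. The swap itself, propyl in place of isopropyl, gives a 2.0-fold lower number from compound 2 to compound 4 (0.30 log units; within the scatter) and so, with the same atoms joined differently, it does not separate these two chains in this measurement. Nothing shown here offers any explanation for these steps.

What the compounds leave open is whether a longer chain, such as butyl or pentyl, on the same carbonyl carbon would carry the number further down than propyl does, or whether the trend ends with compound 4. They also leave open how a chain ending in an amine or a carboxylic acid would read at this position, since every chain shown carries only carbon, apart from the chloro of compound 1.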